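The source may report more compounds than this note shows. Statements on the series, on what has been measured and on what is new or still open speak of the compounds shown alone.

Working notes on the series.

Three compounds of the series carry numbers in a functional assay on MOLT-4 cells (Homo sapiens) for cytotoxicity, with a stated time of 72 h; on this read-out lower numbers stand for stronger inhibition and higher numbers for weaker inhibition. Compound 1 `COc1cc(/C=C2\CCC/C(=C\c3ccccc3[N+](=O)[O-])C2=O)cc(OC)c1OC` gives 702 nM. Compound 2 `O=C1/C(=C/c2ccccc2)CCC/C1=C\c1cccc([N+](=O)[O-])c1` gives 1700 nM. Compound 3 `Cc1ccc(/C=C2\CCC/C(=C\c3ccccc3[N+](=O)[O-])C2=O)cc1` gives 7520 nM. Compound 2 thus stands second highest of the three numbers: compound 1 sits below it, beyond the scatter, and compound 3 sits above it, also beyond the scatter.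

Compound 4 `Cc1ccc(/C=C2\CCC/C(=C\c3cccc([N+](=O)[O-])c3)C2=O)cc1` is not yet measured in this assay . It differs from compound 2 in one place: methyl in place of hydrogen on an aromatic carbon, para to a large group. For the measured compounds named here, no pair of measured compounds shows this change alone, so no measured step can be drawn on. Compound 1 and compound 3 differ in more than one place and tell nothing about a single methyl.

Going by the values given here, with no direct precedent, only a modest step from compound 2 to compound 4 is expected, a 1.5-fold higher number from compound 2 to compound 4 (0.17 log units; within the scatter), with a wide range. For compound 4 the estimate in this assay is 2500 nM, between 900 nM and 7000 nM.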

Compound 4, half-maximal inhibitory concentration: 9530 nM
For compound 4 the middle estimate is 3.8-fold (0.58 log units) below the measured one; the measured number lies above the stated range.
By their numbers in this assay, from the lowest: compound 1; then compound 2; then compounds 3 and 4 (each within the scatter of the next).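

In this assay, methyl in place of hydrogen on an aromatic carbon, para to a large group, gives a 5.6-fold higher number from compound 2 to compound 4 (0.75 log units; beyond the scatter), the only single-place step among the compounds shown. The phenyl to 4-methylphenyl change is therefore not silent at this position: one added carbon, with no hydrogen-bond donor, acceptor or net charge, moves the read-out towards weaker inhibition by more than the scatter. Nothing measured on these compounds accounts for the size of this step, which rests on this one pair alone.

Open, as far as these compounds go, is whether any other group at this place would give a lower or a higher number than methyl, for example an amine, a carboxylic acid or a longer chain such as ethyl. Also open, from the compounds shown here alone, is whether the same methyl step keeps its size on other members.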